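Swapping One Five-Membered Ring for Another

The source may hold more compounds than are shown below. What is called first, only, known or untested is meant among the compounds shown, and "the series" means these compounds.

Compound 1 `Cc1cccc(C(=O)N2CCCC(C(=O)Nc3ccc(Cl)cc3)C2)c1` gives 0% in an ADME assay on PC-3 cells (Homo sapiens) for cytotoxicity, read by WST assay, tested at 100 uM; a lower number here means less inhibition, a higher number more inhibition at the concentration tested (going by the name of the read-out). Compound 2 `O=C(Nc1ccc(Cl)cc1)C1CCCN(C(=O)c2cccc(-c3nccs3)c2)C1` gives 32% in this assay, the higher of the two numbers, and the step of a number 32 percentage points higher from compound 1 to compound 2 (beyond the scatter) went with 1,3-thiazol-2-yl in place of methyl on an aromatic carbon. Compound 3 `Cc1nc(-c2cccc(C(=O)N3CCCC(C(=O)Nc4ccc(Cl)cc4)C3)c2)no1` differs from compound 2 on that aromatic carbon: 5-methyl-1,2,4-oxadiazol-3-yl in place of 1,3-thiazol-2-yl on an aromatic carbon. Going by the values given here, only that one measured step bears on this change, and it shows a five-membered aromatic ring giving far more inhibition than methyl. A modest step of a number 8 percentage points lower from compound 2 to compound 3 (within the scatter) is therefore expected. Compound 3 is estimated at 24%, within 5% to 45%.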

Compound 3, a percentage reported as inhibition, at one concentration (the size of the read-out at that concentration, not a potency): 0%
Compound 3: the middle estimate sits 24 percentage points above what was measured, and the stated range ends above it.
By their numbers in this assay, from the lowest: compounds 1 and 3 (each within the scatter of the next); then compound 2.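

At this position, a five-membered aromatic ring does not bring inhibition by itself: in this assay the change of ring gives a number 32 percentage points lower from compound 2 to compound 3 (beyond the scatter), while 5-methyl-1,2,4-oxadiazol-3-yl in place of methyl gives no change at the digits printed from compound 1 to compound 3 (within the scatter). Of these two rings, only 1,3-thiazol-2-yl goes with a step up from methyl, so the ring's identity matters here. No measurement shown explains the difference between the rings. Still open, from the compounds shown here alone, is how other groups on this carbon would read, such as an unsubstituted phenyl ring, an amine or a carboxylic acid. Also open, going by these compounds, is whether 1,3-thiazol-2-yl with a methyl group added would keep its inhibition.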